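Furan-3-yl in place of 3,5-difluorophenyl on the cyclopropane

The source may report more compounds than this note shows. Statements on the series, on what has been measured and on what is new or still open speak of the compounds shown alone.

Measured so far in a functional assay for agonist activity at G protein-coupled receptor 88 (Homo sapiens), read by HTRF and cAMP accumulation; a higher number here means that more compound is needed for the effect, a lower number that less compound is needed:
compound 1 `CC[C@H](C)[C@H](N)CN(C(=O)[C@@H]1C[C@H]1c1cccc(C)c1)c1ccc(-c2ccccc2)cc1` gives 1200 nM
compound 3 `CC[C@H](C)[C@H](N)CN(C(=O)[C@@H]1C[C@H]1c1cc(F)cc(F)c1)c1ccc(-c2ccccc2)cc1` gives 960 nM
compound 2 `CC[C@H](C)[C@H](N)CN(C(=O)[C@@H]1C[C@H]1C1CCCCC1)c1ccc(-c2ccccc2)cc1` gives > 25000 nM, a limit of the assay and not a number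

Compound 3 holds the lowest of the two numbers recorded in this assay, with compound 1 nearest; the step of a 1.3-fold lower number from compound 1 to compound 3 (0.10 log units; within the scatter) lies within the scatter, so no order between these two is claimed. Compound 2 sits at the limit (the limit of > 25000 nM in this assay, at which 1 of the 3 values shown sits).

Compound 4 `CC[C@H](C)[C@H](N)CN(C(=O)[C@@H]1C[C@H]1c1ccoc1)c1ccc(-c2ccccc2)cc1` differs from compound 3 in one place: furan-3-yl in place of 3,5-difluorophenyl on a saturated ring carbon.

Two kinds of step bear on this change. Exchanging one six-membered aromatic ring of carbon only for another on the same saturated ring carbon gave a 1.3-fold lower number from compound 1 to compound 3 (0.10 log units; within the scatter), within the scatter. Exchanging that ring for cyclohexyl gave an at least 20-fold higher number from compound 1 to compound 2 (1.31 log units; beyond the scatter), and the reverse exchange gave an at least 26-fold lower number from compound 2 to compound 3 (1.41 log units; beyond the scatter), both large. Furan-3-yl keeps a five-membered aromatic ring with 1 hetero atom at the position, so the step from compound 3 to compound 4 is expected to resemble the former kind rather than the latter, though a smaller ring may cost something. The expected step is a 1.9-fold higher number from compound 3 to compound 4 (0.27 log units; within the scatter) in this assay.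

Compound 4 is therefore estimated at 1800 nM, with a range from 700 nM to 6000 nM.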

Compound 4, half-maximal effective concentration: 580 nM
For compound 4 the middle estimate is 3.1-fold (0.49 log units) above the measured one; the measured number lies below the stated range.
By their numbers in this assay, from the lowest: compounds 4, 3 and 1 (each within the scatter of the next, the first and the last beyond it). At a limit, above all of these: compound 2.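

In this assay, within the data shown here, the six-membered aromatic ring of carbon only proves not to be required on this saturated ring carbon: furan-3-yl, a five-membered aromatic ring with 1 hetero atom, gives a 1.7-fold lower number from compound 3 to compound 4 (0.22 log units; within the scatter), while the comparison with the 3-methylphenyl group gives a 2.1-fold lower number from compound 1 to compound 4 (0.32 log units; beyond the scatter), so only this last pair of the three aromatic compounds is separated. The contrast between aromatic and saturated rings at this place now rests on a third aromatic group, with an at least 43-fold lower number from compound 2 to compound 4 (1.63 log units; beyond the scatter). Compound 2 stands at a limit of the assay and not at a number, so this step gives only a bound: the limit of > 25000 nM in this assay, at which 1 of the 4 values shown sits.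

The compounds shown cannot tell whether the oxygen of the furan or simply the aromatic ring carries the result, a question that thiophen-3-yl, furan-2-yl or a pyridyl group at the same place would address. Equally open, as far as these compounds go, is whether the saturated counterpart tetrahydrofuran-3-yl would follow cyclohexyl or furan-3-yl, and how an amine or a carboxylic acid on the aromatic ring would read in this assay.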